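This account rests on a few compounds, and the source may have more. Where it says the series, first, only, none or still open, it means among the compounds named here.

Series notes, cytotoxicity. In a functional assay on HeLa cells (Homo sapiens) for cytotoxicity, read by MTT assay, with a stated time of 48 h (on this read-out lower numbers stand for stronger inhibition and higher numbers for weaker inhibition), compound 1 `CCOC(=O)c1c(-c2cc3ccccc3oc2=O)nn(-c2ccccc2)c1C(=O)OCC` gives 100000 nM, the second highest of the three numbers in hand. Compound 2 `CCOC(=O)c1c(-c2cc3ccccc3oc2=O)nn(-c2ccc(Cl)cc2)c1C(=O)OCC` gives 87000 nM in this assay, and compound 3 `CCOC(=O)c1c(-c2cc3ccccc3oc2=O)nn(-c2ccc(Br)cc2)c1C(=O)OCC` gives 250000 nM. The step of a 1.1-fold lower number from compound 1 to compound 2 (0.06 log units; within the scatter) lies within the scatter, while a 2.5-fold higher number from compound 1 to compound 3 (0.40 log units; beyond the scatter) and a 2.9-fold higher number from compound 2 to compound 3 (0.46 log units; beyond the scatter) are modest. Compound 4 `CCOC(=O)c1c(-c2cc3ccc(OC)cc3oc2=O)nn(-c2ccccc2)c1C(=O)OCC` differs from compound 1 by methoxy in place of hydrogen on an aromatic carbon, a change on the six-membered aromatic ring of carbon only within the fused system, a different ring from the one carrying the chloro of compound 2 and the bromo of compound 3. Within the data shown here, no measured step touches that ring, so none bears directly on this change; the steps that are known all concern the other ring and stay within the scatter or modest. For compound 4 no step beyond the scatter is therefore expected in this assay, no change at the digits printed from compound 1 to compound 4 (within the scatter). The estimate for compound 4 is 100000 nM, with a range from 40000 nM to 250000 nM.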

Compound 4, half-maximal inhibitory concentration: 140000 nM
Compound 4: middle estimate off by 1.4-fold (0.15 log units), on the low side, within the range that was stated.
By their numbers in this assay, from the lowest: compounds 2, 1, 4 and 3 (each within the scatter of the next, the first and the last beyond it).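

Methoxy in place of hydrogen on the six-membered aromatic ring of carbon only, part of the fused system, gives the first reading for this ring in this assay (a 1.4-fold higher number from compound 1 to compound 4 (0.15 log units; within the scatter)). The earlier compounds shown here varied only the other ring, so they said nothing about this place; the series now shows that, at this one place, a methoxy leaves the number within the scatter of compound 1. No measurement at hand bears on why the result stands as it does.

On these data alone, whether an amine, a carboxylic acid or a longer alkoxy chain at this place would also stay within the scatter of compound 1 remains open, as does methoxy elsewhere on this ring. Also open, as far as these compounds go, is how this methoxy behaves when combined with the chloro of compound 2 or the bromo of compound 3.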